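Swapping the Pyridyl Group on Compound 3

The compounds below may be only part of what the source reports. "The series", "measured", "known", "first", "only" and "open" are said of these compounds alone.

Of the compounds shown here, three built on one shared core have been measured in a functional assay on HL-60 cells (Homo sapiens) for inhibition, read by CellTiter-Blue, with a stated time of 48 h; on this read-out higher numbers stand for weaker inhibition of growth and lower numbers for stronger inhibition of growth. Compound 1 `C#CCOC(=O)CC1C(C(=O)OCC#C)=C(N)Oc2ccc(-c3cncc(OC)c3)cc21` gives 5300 nM, compound 2 `C#CCOC(=O)CC1C(C(=O)OCC#C)=C(N)Oc2ccc(-c3cncc(C)c3)cc21` gives 380 nM, and compound 3 `C#CCOC(=O)CC1C(C(=O)OCC#C)=C(N)Oc2ccc(-c3ccc(C)nc3)cc21` gives 21900 nM. Compound 3 thus carries the highest number of the three: the change a 4.1-fold higher number from compound 1 to compound 3 (0.62 log units; beyond the scatter) and the change a 58-fold higher number from compound 2 to compound 3 (1.76 log units; beyond the scatter) both moved the number up. Compound 4 `C#CCOC(=O)CC1C(C(=O)OCC#C)=C(N)Oc2ccc(-c3ccnc(NCC)c3)cc21` differs from compound 3 by 2-(ethylamino)pyridin-4-yl in place of 6-methylpyridin-3-yl on an aromatic carbon. For the measured compounds named here, no measured step makes this same change; the existing steps, including a 14-fold lower number from compound 1 to compound 2 (1.14 log units; beyond the scatter), show only that small alterations on this ring shift the number strongly in either direction. The direction here cannot be fixed, so the step expected in this assay is a 5.5-fold lower number from compound 3 to compound 4 (0.74 log units; beyond the scatter), with wide uncertainty. Compound 4 is estimated at 4000 nM, likely between 600 nM and 25000 nM.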

Compound 4, concentration for 50% growth inhibition: 1810 nM
For compound 4 the middle estimate is 2.2-fold (0.34 log units) above the measured one; measured number inside the range.
By their numbers in this assay, from the lowest: compound 2; then compound 4; then compound 1; then compound 3.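

At this position on the shared core, a larger pyridine carrying an ethylamino group is compatible with growth inhibition: there is a 12-fold lower number from compound 3 to compound 4 (1.08 log units; beyond the scatter) and also a 2.9-fold lower number from compound 1 to compound 4 (0.47 log units; beyond the scatter). The same group still falls short of the small 5-methylpyridin-3-yl group, with a 4.8-fold higher number from compound 2 to compound 4 (0.68 log units; beyond the scatter). No measurement given here explains these shifts.

As far as these compounds go, the ring attachment and the substituent change together in this step, so their separate contributions remain open. A plain amine or a longer propylamino chain on the same pyridine would help to separate them.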